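Swapping pyridin-4-yl for 4-cyanophenyl: what solubility to expect

The source may hold more compounds than are shown below. What is called first, only, known or untested is meant among the compounds shown, and "the series" means these compounds.

Measured in a physicochemical assay for solubility, using the shake flask method, in simulated intestinal fluid, measured as kinetic solubility, with a stated time of 2 h, at 25 degrees C, at pH 6.5 (a higher number here means a more soluble compound, a lower number a less soluble compound), so far:
Compound 1 `Cc1noc(-c2nc(C)c3c(c2N)C(=O)N(Cc2ccc(-c4ccncc4)cc2)C3=O)n1` gives < 5000 nM as a limit of the assay, not a number
Compound 2 `Cc1noc(-c2nc(C)c3c(c2N)C(=O)N(Cc2ccc(-n4cccn4)cc2)C3=O)n1` gives < 5000 nM as a limit of the assay, not a number
Compound 3 `Cc1noc(-c2nc(C)c3c(c2N)C(=O)N(Cc2ccncc2)C3=O)n1` gives 26400 nM as a true measured number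

Among the compounds with values here, compound 3 holds the only true number in this small set, and it stands clear of the limit that the other two compounds share. Compound 4 `Cc1noc(-c2nc(C)c3c(c2N)C(=O)N(Cc2ccc(C#N)cc2)C3=O)n1` is still unmeasured, and the change from compound 3 reads 4-cyanophenyl in place of pyridin-4-yl on a saturated chain carbon bound to an amide-type nitrogen in a ring in one place only. An aromatic ring of carbon only, bearing a triple bond, replaces a six-membered aromatic ring with a hetero atom.

Within the data shown here, the only measured step, a step that the two limits leave unreadable from compound 1 to compound 2, has no readable size and concerns a different change, so it gives no direct guide. Compound 1 and compound 2 also carry a carbon-only aromatic ring on that chain carbon, and what they offer is the limit of < 5000 nM in this assay, at which 2 of the 3 values shown sit, and nothing finer. A fall in this assay beyond the scatter is therefore expected, though this rests on just these two limits. The expected change is a 4.4-fold lower number from compound 3 to compound 4 (0.64 log units; beyond the scatter) in the downward direction, and the result may well arrive as a limit. The estimated value for compound 4 is 6000 nM with a range from 2500 nM to 15000 nM (expected, not measured).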

Compound 4, solubility: < 5000 nM
Compound 4: a limit, no number; the forecaster's own chance of this, stated with the estimate: 55%; middle value at least 1.2-fold (0.07 log units) from the limit.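

Within the data shown here, at this position, on a saturated chain carbon bound to an amide-type nitrogen in a ring, putting 4-cyanophenyl in place of pyridin-4-yl gives the first readable step in this assay: an at least 5.2-fold lower number from compound 3 to compound 4 (0.72 log units; beyond the scatter). From the compounds shown here alone, compound 4 gives < 5000 nM, which is a limit of the assay and not a number, so this step shows a minimum size and the full size stays unknown. Among these compounds, until now no step in this small set could be read, whereas a change in one place now ties the loss of the only true number to the swap of (pyridin-4-yl)methyl for 4-cyanobenzyl, and compound 4 joins the other compounds at the same floor: the limit of < 5000 nM in this assay, at which 3 of the 4 values shown sit.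

The steps that link compound 4 with compound 1 and compound 2 join limits on both sides and cannot be read. Also open, going by these compounds, is whether the fall follows from losing the ring nitrogen or from gaining the nitrile, and whether an amine or a carboxylic acid in place of the nitrile would bring the value back to a true number.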